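Trading 4-fluorophenyl for 3,5-dimethoxyphenyl

A few compounds are considered here, and "the series" means these few. Any claim that something is new, unique, unknown or untested is made for them only; others in the source may bear on it.

In a functional assay on MDA-MB-231 cells (Homo sapiens) for antiproliferative activity, read by MTT assay, with a stated time of 72 h (a higher number here means a weaker inhibitor, a lower number a stronger inhibitor), compound 1 `C#Cc1cccc(NC(=O)CCc2cccc3c2B(O)OC3)c1` gives 1600 nM, compound 2 `O=C(CCc1cccc2c1B(O)OC2)Nc1cccc(-c2ccccc2)c1` gives 220 nM and compound 3 `O=C(CCc1cccc2c1B(O)OC2)Nc1cccc(-c2ccc(F)cc2)c1` gives 250 nM. Compound 3 thus matches compound 2 within the scatter and lies well under compound 1. Phenyl in place of ethynyl gave a 7.3-fold lower number from compound 1 to compound 2 (0.86 log units; beyond the scatter), and 4-fluorophenyl in its place gave a 6.4-fold lower number from compound 1 to compound 3 (0.81 log units; beyond the scatter). Fluoro in place of hydrogen gave only a 1.1-fold higher number from compound 2 to compound 3 (0.06 log units; within the scatter). Compound 4 `COc1cc(OC)cc(-c2cccc(NC(=O)CCc3cccc4c3B(O)OC4)c2)c1` carries 3,5-dimethoxyphenyl in place of 4-fluorophenyl (3,5-dimethoxyphenyl in place of 4-fluorophenyl on an aromatic carbon). Among the compounds with values here, no measured compound carries this group, so the fluoro step is only a weak guide, and no clear change is expected. The expected result is a 1.2-fold higher number from compound 3 to compound 4 (0.08 log units; within the scatter). Compound 4 is estimated at 300 nM, with a range from 100 nM to 900 nM.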

Compound 4, half-maximal inhibitory concentration: 40 nM
For compound 4 the middle estimate is 7.5-fold (0.88 log units) above the measured one; measured number outside the range, below it.
By their numbers in this assay, from the lowest: compound 4; then compounds 2 and 3 (each within the scatter of the next); then compound 1.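

In this assay the swap to 3,5-dimethoxyphenyl gives a 6.3-fold lower number from compound 3 to compound 4 (0.80 log units; beyond the scatter) and a 5.5-fold lower number from compound 2 to compound 4 (0.74 log units; beyond the scatter) even though adding fluoro to phenyl had shifted nothing beyond the scatter, so substituents on this aryl group can matter here. Measured against ethynyl, the change amounts to a 40-fold lower number from compound 1 to compound 4 (1.60 log units; beyond the scatter) and is the largest step in this set. No data on hand explain the gain. The compounds shown leave open whether a single methoxy group would suffice. They also leave open whether ethoxy, hydroxyl or an amine could replace methoxy and keep the gain.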